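The compounds below may be only part of what the source reports. "The series", "measured", "known", "first", "only" and "open" are said of these compounds alone.

Measured so far in a functional assay on PC-3 cells (Homo sapiens) for antiproliferative activity, read by MTT assay, tested at 5 uM; on this read-out lower numbers stand for a weaker effect and higher numbers for a stronger effect at the one concentration tested:
- compound 1 `COc1ccc(C2OC(c3cc(OC)c(OC)c(OC)c3)=NN2C(C)=O)c(OC)c1`: 92%
- compound 2 `COc1cc(C(=O)N/N=C/c2ccccc2F)cc(OC)c1OC`: 81.8%
- compound 3 `COc1ccc(/C=N/NC(=O)c2cc(OC)c(OC)c(OC)c2)c(OC)c1`: 22.2%

Compound 1 gives the highest of the three numbers. Compound 2 sits next, and its value is lower than that of compound 1 by a margin beyond the usual scatter. Compound 3 lies furthest away, far below compound 1. Compound 2 and compound 3 differ from compound 1 in more than one place, so no single-point step can be read from the set, and none is therefore drawn here.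

Compound 4 `COc1cc(C2=NN(C(C)=O)C(c3c(Cl)cccc3Cl)O2)cc(OC)c1OC` has not yet been tested in this assay. Its difference from compound 1 is a single exchange on the shared core: 2,6-dichlorophenyl in place of 2,4-dimethoxyphenyl on a saturated ring carbon. Among the compounds with values here, no step of this kind is covered by the measured compounds, so the size of the step in this assay can only be guessed. The expectation is a moderate move downward, not an extreme one, with a loss of no more than a modest share of the effect of compound 1 thought likely.

Compound 4 is estimated at 72%, with a range from 45% to 92%. This estimate means an expected step of a number 20 percentage points lower from compound 1 to compound 4 (beyond the scatter).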

Compound 4, a percentage reported as inhibition, at one concentration (the size of the read-out at that concentration, not a potency): -2.2%
Beside the measured number, compound 4's estimate is 74.2 percentage points above it; measured number below the stated range.
By their numbers in this assay, from the lowest: compound 4; then compound 3; then compound 2; then compound 1.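

In this assay, within the data shown here, the exchange of 2,4-dimethoxyphenyl for 2,6-dichlorophenyl on the saturated ring carbon gives the only single-place step, a number 94.2 percentage points lower from compound 1 to compound 4 (beyond the scatter), and this is what the earlier compounds could not show: with the shared core held constant, the group at this one position is enough to move the read-out from the highest number in the set to the lowest. The core of compound 1 therefore does not secure the effect by itself, since compound 4 keeps that core and the acetyl group on the ring nitrogen and gives -2.2% at the one concentration tested. Nothing at hand accounts for the size of this step.

The step changes both the kind of substituent and its pattern on the aromatic ring, so the two cannot be separated here. Compounds carrying 2,4-dichlorophenyl, 2,6-dimethoxyphenyl or unsubstituted phenyl at this position would show whether the chlorine atoms, the substitution pattern or the combination goes with the loss of effect.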